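Acrylamide-type thienopyrimidines in a HeLa growth assay

The source may report more compounds than this note shows. Statements on the series, on what has been measured and on what is new or still open speak of the compounds shown alone.

Measured so far:
compound 1, `COc1cccc(Nc2nc(Oc3cccc(NC(=O)C=C(C)C)c3)c3sccc3n2)c1`, 26100 nM
compound 2, `CC/C=C/C(=O)Nc1cccc(Oc2nc(Nc3cccc(OC)c3)nc3ccsc23)c1`, 29400 nM
compound 3, `CC(C)=CC(=O)Nc1cccc(Oc2nc(Nc3cccc(C#N)c3)nc3ccsc23)c1`, 19800 nM

All three values come from a functional assay on HeLa cells (Homo sapiens) for inhibition, read by MTT assay, with a stated time of 72 h; a lower number here means a stronger inhibitor, a higher number a weaker inhibitor. Compound 1 gives 26100 nM and compound 2 gives 29400 nM; the change between them is but-1-en-1-yl in place of 2-methylprop-1-en-1-yl on a carbonyl carbon, and the step is a 1.1-fold higher number from compound 1 to compound 2 (0.05 log units; within the scatter). Compound 3 gives 19800 nM; it differs from compound 1 by cyano in place of methoxy on an aromatic carbon, with a step of a 1.3-fold lower number from compound 1 to compound 3 (0.12 log units; within the scatter). All three numbers lie close together in this assay.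

The unmeasured compound 4, `CC/C=C/C(=O)Nc1cccc(Oc2nc(Nc3cccc(C#N)c3)nc3ccsc23)c1`, is built from compound 3 by but-1-en-1-yl in place of 2-methylprop-1-en-1-yl on a carbonyl carbon. The change is the same one as that from compound 1 to compound 2: the group that leaves, the group that enters and the place are described in the same words for both pairs. The core of compound 3 differs from that of compound 1 by the change given above as cyano in place of methoxy on an aromatic carbon.

Because the earlier instance of this change gave a 1.1-fold higher number from compound 1 to compound 2 (0.05 log units; within the scatter), a step of similar size is expected here, namely a 1.1-fold higher number from compound 3 to compound 4 (0.05 log units; within the scatter). On that basis compound 4 is estimated at 22000 nM in this assay, with a range expected from 10000 nM to 45000 nM. Within the data shown here, only one prior instance of the change is available, so the expectation rests on a single step and on the general closeness of the three measured values.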

Compound 4, half-maximal inhibitory concentration: 69400 nM
Estimate against measurement, compound 4: 3.2-fold (0.50 log units) below; the measured number lies above the stated range.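

In this assay, but-1-en-1-yl in place of 2-methylprop-1-en-1-yl on the carbonyl carbon gives a 3.5-fold higher number from compound 3 to compound 4 (0.54 log units; beyond the scatter), and cyano in place of methoxy on the aromatic carbon, read with the but-1-en-1-yl amide in place, gives a 2.4-fold higher number from compound 2 to compound 4 (0.37 log units; beyond the scatter). The size of the first change therefore does not carry over from the core of compound 1 to the core of compound 3: the same change on two cores in this assay, a 1.1-fold higher number (0.05 log units; within the scatter) from compound 1 to compound 2 and a 3.5-fold higher number (0.54 log units; beyond the scatter) from compound 3 to compound 4, 3.1-fold (0.49 log units) apart, beyond the scatter of two such steps. The four compounds form a single square, so the cyano change shows the same mismatch, the two changes do not simply add up in this set, and nothing here shows whether this holds beyond these compounds or why the steps differ: the same change on two cores in this assay, a 1.3-fold lower number (0.12 log units; within the scatter) from compound 1 to compound 3 and a 2.4-fold higher number (0.37 log units; beyond the scatter) from compound 2 to compound 4, 3.1-fold (0.49 log units) apart, beyond the scatter of two such steps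

The compounds shown leave open whether the same dependence on the partner group appears with other groups on the carbonyl carbon, such as a longer chain like pent-1-en-1-yl or a saturated butyl chain. They also leave open whether it appears with other groups in place of cyano and methoxy on the aromatic carbon, such as an amine or a carboxylic acid.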